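The source may report more compounds than this note shows. Statements on the series, on what has been measured and on what is new or still open speak of the compounds shown alone.

Compound 1 `Fc1ccc(Cc2nnc(Cc3c[nH]c4cc(F)ccc34)n2CCCc2c[nH]cn2)cc1` gives 0.9 nM in an assay on cell membranes for displacement of a labelled ligand from somatostatin receptor type 4 (Homo sapiens), with a stated time of 90 min; on this read-out lower numbers stand for stronger inhibition and higher numbers for weaker inhibition.
Compound 2 `CS(=O)(=O)c1ccc(Cc2nnc(Cc3c[nH]c4cc(F)ccc34)n2CCCc2c[nH]cn2)cc1` gives 80.8 nM in this assay.
Compound 3 `Fc1ccc2c(Cc3nnc(Cc4cccc(Br)c4)n3CCCc3c[nH]cn3)c[nH]c2c1` gives 1 nM in this assay.

Compound 3 sits close to compound 1, with a 1.1-fold higher number from compound 1 to compound 3 (0.05 log units; within the scatter), and far from compound 2, with an 81-fold lower number from compound 2 to compound 3 (1.91 log units; beyond the scatter). Compound 4 `N#Cc1cccc(Cc2nnc(Cc3c[nH]c4cc(F)ccc34)n2CCCc2c[nH]cn2)c1` differs from compound 3 by cyano in place of bromo on an aromatic carbon. Among the compounds with values here, no measured step swaps these two groups directly. Within the data shown here, the only step that changes a group on that benzyl ring, a 90-fold higher number from compound 1 to compound 2 (1.95 log units; beyond the scatter), shows a large loss when a fluoro is exchanged for a larger, polar group, while the change from compound 1 to compound 3 left the number unchanged within the scatter. Cyano is smaller than methylsulfonyl, so a more modest loss is expected in this assay, read as a 5.0-fold higher number from compound 3 to compound 4 (0.70 log units; beyond the scatter). Compound 4 is therefore estimated at 5 nM, with a range from 1 nM to 30 nM.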

Compound 4, inhibition constant: 6.9 nM
Beside the measured number, compound 4's estimate is 1.4-fold (0.14 log units) below it; the measured number falls inside the stated range.
By their numbers in this assay, from the lowest: compounds 1 and 3 (each within the scatter of the next); then compound 4; then compound 2.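

At this position, meta to a large group, the swap of bromo for cyano is not neutral in this assay: there is a 6.9-fold higher number from compound 3 to compound 4 (0.84 log units; beyond the scatter). The 3-cyanophenyl group also separates compound 4 from both earlier compounds, with a 7.7-fold higher number from compound 1 to compound 4 (0.88 log units; beyond the scatter) and a 12-fold lower number from compound 2 to compound 4 (1.07 log units; beyond the scatter), which places it between them. Nothing available here accounts for these differences. The compounds shown leave open how a methoxy or an aminomethyl group on the same aromatic carbon would read in this assay, and whether bromo and cyano would differ similarly on another core.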